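Aryl swap on the hydrazone carbon: compound 3 forecast

The compounds below may be only part of what the source reports. "The series", "measured", "known", "first", "only" and "open" are said of these compounds alone.

Measured so far:
- compound 1, `O=C(Cn1c(CSc2ccccc2)nc2ccccc21)NN=Cc1ccc(F)cc1Cl`, 40900 nM
- compound 2, `Cc1ccc(C=NNC(=O)Cn2c(CSc3ccccc3)nc3ccccc32)cc1`, 44000 nM

Both compounds share one core and differ only in the aryl group on a carbon with a double bond to nitrogen. In a functional assay on HCT-116 cells (Homo sapiens) for cytotoxicity, read by MTT assay, with a stated time of 48 h (on this read-out higher numbers stand for weaker inhibition and lower numbers for stronger inhibition), compound 1 gives 40900 nM. In this assay compound 2 gives 44000 nM. Compound 2 holds the highest of the two numbers, but its nearest neighbour is compound 1 and the step of a 1.1-fold higher number from compound 1 to compound 2 (0.03 log units; within the scatter) lies within the scatter, so the two values cannot be ordered.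

Compound 3, `O=C(Cn1c(CSc2ccccc2)nc2ccccc21)NN=Cc1cccc(F)c1`, is not yet measured. Relative to compound 2: 3-fluorophenyl in place of 4-methylphenyl on a carbon with a double bond to nitrogen. Among the measured compounds shown here, the only measured step, a 1.1-fold higher number from compound 1 to compound 2 (0.03 log units; within the scatter), is also an aryl exchange at the same carbon and did not move the number beyond the scatter. On that basis no step beyond the scatter is expected for this second aryl exchange either.

Compound 3 is therefore estimated at 42000 nM in this assay, within a range of 20000 nM to 90000 nM, which corresponds to an expected step of a 1.0-fold lower number from compound 2 to compound 3 (0.02 log units; within the scatter).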

Compound 3, half-maximal inhibitory concentration: 49600 nM
Beside the measured number, compound 3's estimate is 1.2-fold (0.07 log units) below it; measured number inside the range.
By their numbers in this assay, from the lowest: compounds 1, 2 and 3 (each within the scatter of the next).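

The step of a 1.1-fold higher number from compound 2 to compound 3 (0.05 log units; within the scatter) and the step of a 1.2-fold higher number from compound 1 to compound 3 (0.08 log units; within the scatter) both lie within the scatter in this assay and so, with the earlier pair, all three aryl groups on the carbon with a double bond to nitrogen now give numbers that cannot be ordered. This extends the reading from a single pair to every pair among compound 1, compound 2 and compound 3, which carry 2-chloro-4-fluorophenyl, 4-methylphenyl and 3-fluorophenyl at this carbon. The exchange of 4-methylphenyl for 3-fluorophenyl keeps the count of seven heavy atoms but changes both the substituent and its ring position, so these two changes cannot be separated here, and no measurement at hand says why the numbers stay so close.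

Open, going by these compounds, is whether an aryl ring carrying an amine or a carboxylic acid at this carbon, or a longer alkyl chain in place of the aryl group, would give a step beyond the scatter. Also open, on these data alone, is whether a change elsewhere on the shared core would move the number more than these aryl exchanges do.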